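Phenyl to benzyl on the tetrazole of compound 3

This account rests on a few compounds, and the source may have more. Where it says the series, first, only, none or still open, it means among the compounds named here.

Compound 3 `CCCCCCCCc1ccc(OCC(=O)Cn2nnnc2-c2ccccc2)cc1` is measured in an assay on microsomes from brain for inhibition of Fatty-acid amide hydrolase 1 (Rattus norvegicus), read by fluorescence and HPLC, with a stated time of 60 min (a higher number here means a weaker inhibitor, a lower number a stronger inhibitor), at 71 nM, the highest number among the three compounds measured. Its nearest neighbour is compound 2 `CCCCCCCCc1ccc(OCC(=O)Cn2nnc(C(=O)O)n2)cc1` with 41 nM, a gap within the scatter, while compound 1 `CCCCCCCCc1ccc(OCC(=O)Cn2nnc(-c3cccc(C(=O)OC)c3)n2)cc1` with 34 nM lies farther off, a gap beyond the scatter. Compound 4 `CCCCCCCCc1ccc(OCC(=O)Cn2nnnc2Cc2ccccc2)cc1` has not been measured; it differs from compound 3 by benzyl in place of phenyl on an aromatic carbon. Going by the values given here, the single measured step, a 1.2-fold higher number from compound 1 to compound 2 (0.08 log units; within the scatter), concerns a different exchange on a different part of the core and gives no direct guidance for the change from compound 3 to compound 4. Among the compounds with values here, with no comparable step available, the expectation rests on the spread of the three known values, which all sit within a narrow band. The number expected for compound 4 in this assay is therefore close to that of compound 3, with an estimated step of a 1.0-fold lower number from compound 3 to compound 4 (0.01 log units; within the scatter) that is not expected to exceed the scatter. Compound 4 is estimated at 70 nM, within a range from 30 nM to 170 nM.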

Compound 4, half-maximal inhibitory concentration: 320 nM
For compound 4 the middle estimate is 4.6-fold (0.66 log units) below the measured one; measured number above the stated range.
By their numbers in this assay, from the lowest: compounds 1, 2 and 3 (each within the scatter of the next, the first and the last beyond it); then compound 4.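

In this assay, benzyl in place of phenyl on this aromatic carbon gives a 4.5-fold higher number from compound 3 to compound 4 (0.65 log units; beyond the scatter), a step beyond the scatter. Going by these compounds alone, this is the first measured sign that the group at this place on the five-membered aromatic ring with 4 nitrogen affects the number, since the only earlier step lay within the scatter and involved a different exchange at a different place. The change is also a small one: both groups hold one six-membered aromatic ring of carbon only, with no hydrogen-bond donors or acceptors and no net charge, and nothing at hand explains the rise.

The compounds shown leave open whether a longer chain, such as phenethyl, would raise the number further. They also leave open whether an amine or a methoxy group on the benzyl ring would change it.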